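The source may hold more compounds than are shown below. What is called first, only, known or untested is meant among the compounds shown, and "the series" means these compounds.

Measured so far in an assay on isolated protein for inhibition of Neprilysin (Oryctolagus cuniculus); a higher number here means a weaker inhibitor, a lower number a stronger inhibitor:

- compound 1 `O=C(NCC(=O)N1[C@@H](c2ccccc2)CC[C@H]1C(=O)O)[C@@H](S)Cc1ccc(O)cc1`: 3.4 nM
- compound 2 `Nc1ccc(C[C@H](S)C(=O)NCC(=O)N2[C@@H](c3ccccc3)CC[C@H]2C(=O)O)cc1`: 1.8 nM
- compound 3 `Cc1ccccc1[C@@H]1CC[C@H](C(=O)O)N1C(=O)CNC(=O)[C@@H](S)Cc1ccccc1`: 8.5 nM

Compound 3 gives the highest number of the three in this assay; compound 1 stands nearest to it and compound 2 furthest, both beyond the scatter. Among the measured compounds shown here, the only step measured, a 1.9-fold lower number from compound 1 to compound 2 (0.28 log units; within the scatter), concerns a substituent on an aromatic carbon and lies within the scatter.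

Compound 4 `Cc1ccccc1[C@H]1CC[C@H](C(=O)O)N1C(=O)CNC(=O)[C@@H](S)Cc1ccccc1` is the untested epimer: the two compounds have the same atoms and bonds and differ only in configuration as drawn: 1 of 3 stereo elements differ; a stereocentre at a saturated ring carbon is drawn S in compound 3 and R in compound 4. For the measured compounds named here, no measured step bears on this change; compounds 1, 2 and 3 all share the configuration drawn for compound 3 at that ring carbon, so nothing shows what inverting it does. The change is therefore judged from the structural alteration alone. An inversion at a ring stereocentre in a set of potent inhibitors is expected to cost potency, most likely beyond the scatter, but the size is uncertain in both directions.

For compound 4 the expected step is a 4.7-fold higher number from compound 3 to compound 4 (0.67 log units; beyond the scatter), and its estimated value in this assay is 40 nM, with a range from 8 nM to 400 nM.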

Compound 4, half-maximal inhibitory concentration: 25 nM
The estimate for compound 4 lay 1.6-fold (0.20 log units) above the measured number; low and high end bracket the measured number.
By their numbers in this assay, from the lowest: compounds 2 and 1 (each within the scatter of the next); then compound 3; then compound 4.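

In this assay, among the compounds shown here, the configuration at the saturated ring carbon has a measurable effect, which the earlier compounds could not show: drawing this stereocentre R rather than S gives a 2.9-fold higher number from compound 3 to compound 4 (0.47 log units; beyond the scatter). The cost is modest, and compound 4 still gives 25 nM, so for this pair the inversion weakens inhibition without abolishing it. The shift can be assigned to this one stereocentre because nothing else separates the pair: the fact that compounds 3 and 4 differ only in the configuration as drawn.

As far as these compounds go, whether the inversion costs about the same without the methyl group of compounds 3 and 4, as in the aromatic ring of compound 1 or compound 2, remains open. Also open, from the compounds shown here alone, is how an ethyl or methoxy group in place of that methyl group would behave with either configuration at the ring carbon.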